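This account rests on a few compounds, and the source may have more. Where it says the series, first, only, none or still open, it means among the compounds named here.

Working notes on the series built around the core of compound 1 `CC(C)(C)n1ncc(OCc2nnc(-c3ccc(Br)cc3)o2)c(Cl)c1=O`. In a functional assay on the whole organism for inhibition, with Mythimna separata as the target, with a stated time of 5 days (on this read-out higher numbers stand for an effect only at larger amounts of compound and lower numbers for an effect already at smaller amounts), compound 1 gives 21.4 ug/mL. Compound 2 `CC(C)(C)n1ncc(OCc2nnc(-c3ccccc3Cl)o2)c(Cl)c1=O` gives 61.2 ug/mL in this assay, a step of a 2.9-fold higher number from compound 1 to compound 2 (0.46 log units; beyond the scatter). Compound 3 `Cc1nnc(COc2cnn(C(C)(C)C)c(=O)c2Cl)o1` reaches only the limit of the assay and not a number: in this assay compound 3 gives > 300 ug/mL. Compound 3 thus stands at the weak end of the measured set, at the limit of > 300 ug/mL in this assay, at which 1 of the 3 values shown sits. The steps leading to it are an at least 14-fold higher number from compound 1 to compound 3 (1.14 log units; beyond the scatter) and an at least 4.9-fold higher number from compound 2 to compound 3 (0.69 log units; beyond the scatter).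

Compound 4 `Cc1cc(C)cc(-c2nnc(COc3cnn(C(C)(C)C)c(=O)c3Cl)o2)c1` is not yet measured. It differs from compound 3 by 3,5-dimethylphenyl in place of methyl on an aromatic carbon. The two steps above bear directly on this change, since both run the other way: each replaces an aryl group on the aromatic carbon with methyl, and each carries the number to the limit. Putting an aryl group back on that aromatic carbon, the expected step for compound 4 is an at least 7.5-fold lower number from compound 3 to compound 4 (0.87 log units; beyond the scatter), a large fall in the number. Neither measured aryl group is 3,5-dimethylphenyl, so the size rests on two points only. The estimate for compound 4 in this assay is 40 ug/mL, with a range from 15 ug/mL to 150 ug/mL.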

Compound 4, half-maximal effective concentration: > 300 ug/mL
Compound 4 was reported as a limit; the forecaster's own chance of this, stated with the estimate: 10%; middle value at least 7.5-fold (0.87 log units) away from the limit.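

Compound 4 shows that an aryl group on this aromatic carbon does not by itself carry activity: the change to 3,5-dimethylphenyl gives an at least 14-fold higher number from compound 1 to compound 4 (1.14 log units; beyond the scatter), and it gives an at least 4.9-fold higher number from compound 2 to compound 4 (0.69 log units; beyond the scatter). The earlier link between an aryl group here and a readable number therefore holds for compound 1 and compound 2, while compound 4 goes against it, so the kind of aryl group matters and not only its presence. In this assay, compound 4 joins compound 3 at a limit of the assay rather than a number, which leaves the step between them unreadable and gives no readable gain from replacing methyl with 3,5-dimethylphenyl: the limit of > 300 ug/mL in this assay, at which 2 of the 4 values shown sit.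

It remains open whether the difference among these three aryl groups follows from the halogens, from the two methyl groups, or from where those groups sit on the ring. A plain phenyl, 4-methylphenyl or 3,5-dichlorophenyl group would help separate these possibilities, and the compounds shown also do not say how compound 3 and compound 4 compare beyond their shared limit.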